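This account rests on a few compounds, and the source may have more. Where it says the series, first, only, none or still open, it means among the compounds named here.

Of the compounds shown here, three sharing one core have been measured in a functional assay on BT-549 cells (Homo sapiens) for inhibition, read by sulforhodamine B assay, with a stated time of 48 h, tested at 10 uM; a lower number here means a stronger effect, a higher number a weaker effect of the compound at the concentration tested. Compound 1, `COc1cc(Cl)cc(-c2nn(-c3cccc(NC(=O)Nc4ccc(Cl)c(Cl)c4)c3)cc2-c2ccncc2)c1`, gives 29.4%. Compound 2, `COc1cc(Cl)cc(-c2nn(-c3cccc(NC(=O)c4cccc(C(F)(F)F)c4)c3)cc2-c2ccncc2)c1`, gives 89.5%. Compound 3, `O=C(Nc1cccc(-n2cc(-c3ccncc3)c(-c3cc(O)cc(Cl)c3)n2)c1)c1cc(C(F)(F)F)cc(C(F)(F)F)c1`, gives 73.4%, the second highest of the three numbers, beyond the scatter from both compound 2 above it and compound 1 below it. Among the measured compounds shown here, the one measured step, a number 60.1 percentage points higher from compound 1 to compound 2 (beyond the scatter), concerns the group on the carbonyl carbon and was large. Compound 4, `COc1cc(Cl)cc(-c2nn(-c3cccc(NC(=O)c4cc(C(F)(F)F)cc(C(F)(F)F)c4)c3)cc2-c2ccncc2)c1`, has not yet been measured. It differs from compound 3 by methyl in place of hydrogen on an oxygen on an aromatic ring, so that a 3-chloro-5-hydroxyphenyl becomes a 3-chloro-5-methoxyphenyl. For the measured compounds named here, no measured step changes hydroxy to methoxy, so the step from compound 1 to compound 2 does not bear on this change; compound 2 also carries the methoxy and gives 89.5%. Compound 4 is therefore expected to stay close to compound 3, with the step of a number 1.6 percentage points higher from compound 3 to compound 4 (within the scatter) expected to lie within the scatter. The estimate for compound 4 is 75%, ranging from 50% to 95%.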

Compound 4, a percentage reported as activity, at one concentration (the size of the read-out at that concentration, not a potency): 96.8%
Beside the measured number, compound 4's estimate is 21.8 percentage points below it; measured number outside the range, above it.
By their numbers in this assay, from the lowest: compound 1; then compound 3; then compounds 2 and 4 (each within the scatter of the next).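

Placing methyl on the oxygen of the 3-chloro-5-hydroxyphenyl group gives the first measured hydroxy to methoxy step in this assay, and the effect weakens: the read-out is a number 23.4 percentage points higher from compound 3 to compound 4 (beyond the scatter) in this one pair. So this oxygen is not indifferent to what it carries, at least with the two trifluoromethyl groups of compound 3 in place. The added trifluoromethyl leaves no readable difference, with a number 7.3 percentage points higher from compound 2 to compound 4 (within the scatter) and no measurement at hand bears on the reason for either step.

As far as these compounds go, it remains open whether the free hydroxy would also go with a stronger effect alongside the carbonyl group of compound 1, which carries the methoxy and gives 29.4% in this assay. An amine at this place, or a longer chain such as ethoxy on the oxygen, also remains untested among the compounds shown.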